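The compounds below may be only part of what the source reports. "The series", "measured", "known", "first", "only" and "open" are said of these compounds alone.

Working notes on a carnitine-derived series. Compound 1 `CCCCCCCCCCCS(=O)(=O)N[C@@H](CC(=O)[O-])C[N+](C)(C)C` is the sulfonamide member; in an assay on mitochondria for binding affinity to carnitine O-palmitoyltransferase 1, muscle isoform (Rattus norvegicus) (on this read-out lower numbers stand for stronger inhibition and higher numbers for weaker inhibition), compound 1 gives 5800 nM. Compound 2 `CCCCCCCCOC(=O)N[C@@H](CC(=O)[O-])C[N+](C)(C)C` is the carbamate member; in this assay compound 2 gives 80100 nM. Of the two numbers shown, compound 2 has the higher one, and its gap to the nearest number, that of compound 1, lies beyond the usual scatter. Compound 3 `CCCCCCCCOC(=O)N[C@H](CC(=O)[O-])C[N+](C)(C)C` has not been measured. Its relation to compound 2: the two compounds have the same atoms and bonds and differ only in configuration as drawn: 1 of 1 stereo elements differ; a stereocentre at a saturated chain carbon is drawn S in compound 2 and R in compound 3. For the measured compounds named here, no pair of measured compounds differs only in configuration, so the size of such a step cannot be read from this series. In this assay the step from compound 2 to compound 3 is expected to be a 2.5-fold higher number from compound 2 to compound 3 (0.40 log units; beyond the scatter), toward a higher number and beyond the scatter. Compound 3 is accordingly estimated at 200000 nM, with a range from 40000 nM to 1000000 nM. A result that returns only a limit rather than a number is a real possibility for compound 3.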

Compound 3, half-maximal inhibitory concentration: > 300000 nM
Compound 3 gave a limit, no number; the forecaster's own chance of this, stated with the estimate: 35%; at least 1.5-fold (0.17 log units) between middle value and limit.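

In this assay compound 3 reads > 300000 nM, which is a limit of the assay and not a number. The series now holds a measured step in configuration alone, and at this saturated chain carbon, going from S to R gives an at least 3.7-fold higher number from compound 2 to compound 3 (0.57 log units; beyond the scatter), so the drawn configuration at this position counts in this assay, although only the minimum size of the step can be read. The change can be assigned to configuration because no other difference exists: the fact that compounds 2 and 3 differ only in the configuration as drawn.

The compounds shown leave open how far the true value of compound 3 lies past its limit, and whether the same change from S to R has a similar size in the sulfonamide compound 1. Also open, from the compounds shown here alone, is how an amide in place of the carbamate, or a longer chain on the carbamate, would read at either configuration.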